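Thiophene for benzyl on the bicyclic core of compound 1

A few compounds are considered here, and "the series" means these few. Any claim that something is new, unique, unknown or untested is made for them only; others in the source may bear on it.

Compound 1 `C=C(Br)C(=O)Nc1cccc(-c2cn3nc(Cc4ccccc4)sc3n2)c1` carries a (1-bromoethenyl)carbonyl on the aniline nitrogen and a benzyl on the fused core. In a functional assay on CCRF-CEM cells (Homo sapiens) for inhibition, read by cell counting, with a stated time of 3 days (a lower number here means a stronger inhibitor, a higher number a weaker inhibitor), compound 1 gives 4200 nM, the lower of the two numbers reported so far. Compound 2 `Nc1cccc(-c2cn3nc(Cc4ccccc4)sc3n2)c1` lacks the acyl group and gives 37000 nM in this assay; the step of an 8.8-fold higher number from compound 1 to compound 2 (0.94 log units; beyond the scatter) is modest but beyond the scatter. Compound 3 `COc1ccc(-c2nn3cc(-c4cccc(N)c4)nc3s2)cc1` has a 4-methoxyphenyl attached directly to the core and no acyl group; its value in this assay, >= 250000 nM, is a limit of the assay rather than a number (the limit of >= 250000 nM in this assay, at which 1 of the 3 values shown sits).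

Compound 4 `C=C(Br)C(=O)Nc1cccc(-c2cn3nc(-c4cccs4)sc3n2)c1` differs from compound 1 by thiophen-2-yl in place of benzyl on an aromatic carbon. For the measured compounds named here, no measured step concerns this position directly: the only measured step, an 8.8-fold higher number from compound 1 to compound 2 (0.94 log units; beyond the scatter), alters the nitrogen substituent. What the values show is that compound 2, with benzyl, gives a number, whereas compound 3, with an aryl bound directly to the core, gives only a limit; compound 4 likewise has its aromatic ring attached directly. A weaker result is therefore expected, with wide uncertainty, in this assay: compound 4 is estimated at 15000 nM, within 3000 nM to 90000 nM, meaning an expected step of a 3.6-fold higher number from compound 1 to compound 4 (0.55 log units; beyond the scatter).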

Compound 4, half-maximal inhibitory concentration: 410 nM
Compound 4: middle estimate off by 37-fold (1.56 log units), on the high side, and the stated range ends above it.
By their numbers in this assay, from the lowest: compound 4; then compound 1; then compound 2. At a limit, above all of these: compound 3.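

In this assay, for the compounds shown here, replacing benzyl with thiophen-2-yl on the core gives a 10-fold lower number from compound 1 to compound 4 (1.01 log units; beyond the scatter), so this position, on which no earlier step bore, clearly moves the number, and a directly attached aromatic ring is compatible with the better value while the (1-bromoethenyl)carbonyl on the nitrogen stays in place. Compound 3 also carries an aryl bound directly to the core, but it differs from compound 4 in more than one place, so it cannot be read for this position, and its value is a limit of the assay: the limit of >= 250000 nM in this assay, at which 1 of the 4 values shown sits. Nothing measured in this set accounts for the step from benzyl to thiophen-2-yl.

As far as these compounds go, the ring and its link to the core change together here, so it remains open whether phenyl bound directly to the core would read like thiophen-2-yl, or thiophen-2-ylmethyl like benzyl. Also open, from the compounds shown here alone, are whether the step carries over to the compounds with a free aniline nitrogen, and how thiophen-3-yl, or an amine or a carboxylic acid on the thiophene, would read in this assay.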